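Chloro in Place of Methoxy: an Expected Antiproliferative Value

A few compounds are considered here, and "the series" means these few. Any claim that something is new, unique, unknown or untested is made for them only; others in the source may bear on it.

Measured in a functional assay on HepG2 cells (Homo sapiens) for antiproliferative activity, read by MTT assay, with a stated time of 72 h (on this read-out higher numbers stand for weaker inhibition and lower numbers for stronger inhibition), so far:
Compound 1 `COc1ccc(-c2nnc(-c3nn(C)c4ccccc34)o2)cc1` gives 19500 nM.
Compound 2 `Cn1nc(-c2nnc(-c3ccc(O)cc3)o2)c2ccccc21` gives 86400 nM.

Within the data shown here, compound 1 holds the lower of the two numbers; the only measured step is a 4.4-fold higher number from compound 1 to compound 2 (0.65 log units; beyond the scatter). Compound 3 `Cn1nc(-c2nnc(-c3ccc(Cl)cc3)o2)c2ccccc21` differs from compound 1 by chloro in place of methoxy on an aromatic carbon. Among the measured compounds shown here, the step from compound 1 to compound 2 concerns only the methyl on that oxygen, not removal of the whole methoxy, so it bears on compound 3 only loosely; no measured step covers chloro directly. No change beyond the scatter is therefore expected in this assay, with the step estimated as a 1.3-fold lower number from compound 1 to compound 3 (0.11 log units; within the scatter). Compound 3 is expected to give about 15000 nM, within 5000 nM to 50000 nM.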

Compound 3, half-maximal inhibitory concentration: 42000 nM
For compound 3 the middle estimate is 2.8-fold (0.45 log units) below the measured one, within the range that was stated.
By their numbers in this assay, from the lowest: compound 1; then compound 3; then compound 2.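

In this assay, the position para to a large group proves sensitive to full replacement of the oxygen substituent, not only to loss of its methyl: chloro in place of methoxy gives a 2.2-fold higher number from compound 1 to compound 3 (0.33 log units; beyond the scatter). Chloro in place of hydroxy gives a 2.1-fold lower number from compound 2 to compound 3 (0.31 log units; beyond the scatter), placing the chloro compound between the other two, with methoxy giving the lowest number of the three groups. Nothing available explains this order. As far as these compounds go, whether an amine, a carboxylic acid or a longer chain such as ethoxy at this position would give a number lower than that of compound 1 remains open.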